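Methoxy on the sulfonyl phenyl ring: compound 4

The compounds below may be only part of what the source reports. "The series", "measured", "known", "first", "only" and "open" are said of these compounds alone.

Compound 1 `COC(=O)c1ccc(C2SCC(=O)N2c2ccc(N3CCN(S(=O)(=O)c4ccc(F)cc4)CC3)cn2)c(OC)c1`: 78300 nM
Compound 2 `COC(=O)c1ccc(C2SCC(=O)N2c2ccc(N3CCN(Cc4ccc(Cl)c(Cl)c4)CC3)cn2)c(OC)c1`: 61000 nM
Compound 3 `COC(=O)c1ccc(C2SCC(=O)N2c2ccc(N3CCN(S(=O)(=O)c4ccccc4)CC3)cn2)c(OC)c1`: 52900 nM

All three were run in a functional assay on Jurkat cells (Homo sapiens) for antiproliferative activity, read by MTT assay and trypan blue exclusion, with a stated time of 72 h; on this read-out higher numbers stand for weaker inhibition and lower numbers for stronger inhibition. The steps to compound 3 from its neighbours, a 1.5-fold lower number from compound 1 to compound 3 (0.17 log units; within the scatter) and a 1.2-fold lower number from compound 2 to compound 3 (0.06 log units; within the scatter), lie within the scatter, so compound 3 stands level with the other two. Compound 4 `COC(=O)c1ccc(C2SCC(=O)N2c2ccc(N3CCN(S(=O)(=O)c4ccc(OC)cc4)CC3)cn2)c(OC)c1` differs from compound 3 by methoxy in place of hydrogen on an aromatic carbon. For the measured compounds named here, the nearest precedent is a 1.5-fold lower number from compound 1 to compound 3 (0.17 log units; within the scatter), where fluoro in place of hydrogen on the phenylsulfonyl ring gave nothing beyond the scatter; swapping the whole group, a 1.3-fold lower number from compound 1 to compound 2 (0.11 log units; within the scatter), was equally flat. Hence the expected step is a 1.1-fold higher number from compound 3 to compound 4 (0.04 log units; within the scatter), nothing beyond the scatter. Compound 4 is estimated at 58000 nM, with a range from 25000 nM to 140000 nM.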

Compound 4, half-maximal inhibitory concentration: 45200 nM
Compound 4: middle estimate off by 1.3-fold (0.11 log units), on the high side; low and high end bracket the measured number.
By their numbers in this assay, from the lowest: compounds 4, 3, 2 and 1 (each within the scatter of the next).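

In this assay, methoxy on the aromatic carbon of the phenylsulfonyl ring leaves the read-out flat (a 1.2-fold lower number from compound 3 to compound 4 (0.07 log units; within the scatter)). Methoxy in place of fluoro on that carbon also stays within the scatter (a 1.7-fold lower number from compound 1 to compound 4 (0.24 log units; within the scatter)), so hydrogen, fluoro and methoxy cannot be told apart at this position. The (4-methoxyphenyl)sulfonyl group also stands level with 3,4-dichlorobenzyl on the ring nitrogen (a 1.3-fold lower number from compound 2 to compound 4 (0.13 log units; within the scatter)). No evidence on hand accounts for this flatness. Still open, from the compounds shown here alone, is whether an amine or a carboxylic acid on this ring would move the number beyond the scatter.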